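This account rests on a few compounds, and the source may have more. Where it says the series, first, only, none or still open, it means among the compounds named here.

Series notes, the step from compound 3 to compound 4.

Three analogues sharing one core have been measured in a functional assay for agonist activity at Free fatty acid receptor 1 (Homo sapiens), read by FLIPR, in the presence of a further agent that is not named here; on this read-out higher numbers stand for an effect only at larger amounts of compound and lower numbers for an effect already at smaller amounts. Compound 1 `Cc1cccc(Oc2ccc(CC3SC(=O)NC3=O)cc2)n1` gives 2620 nM in this assay. Compound 2 `Cc1cccc(Oc2ccc(CC3SC(=O)NC3=O)cc2)c1` gives 203 nM in this assay. Compound 3 `Cc1ccc(Oc2ccc(CC3SC(=O)NC3=O)cc2)c(C)c1` gives 121 nM in this assay, the lowest of the three numbers; its gap to compound 2 lies within the scatter, while its gap to compound 1 lies beyond it. Among the measured compounds shown here, the one single-point step available, a 13-fold lower number from compound 1 to compound 2 (1.11 log units; beyond the scatter), concerns the aromatic ring attached through oxygen and does not touch the substituents of that ring.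

Compound 4 `Cc1ccccc1Oc1ccc(CC2SC(=O)NC2=O)cc1` is not yet measured. The change from compound 3 is hydrogen in place of methyl on an aromatic carbon, the methyl that sits para to a large group. For the measured compounds named here, no measured pair isolates this change; the values of compound 2 and compound 3 only show that two differently methylated phenyl rings sit within the scatter of each other. On that basis no step beyond the scatter is expected in this assay: the estimated step is a 1.7-fold higher number from compound 3 to compound 4 (0.22 log units; within the scatter). Compound 4 is therefore expected to give about 200 nM in this assay, with a range from 80 nM to 500 nM.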

Compound 4, half-maximal effective concentration: 124 nM
Estimate against measurement, compound 4: 1.6-fold (0.21 log units) above; the measured number falls inside the stated range.
By their numbers in this assay, from the lowest: compounds 3, 4 and 2 (each within the scatter of the next); then compound 1.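

In this assay, hydrogen in place of methyl on the aromatic carbon para to a large group gives a 1.0-fold higher number from compound 3 to compound 4 (0.01 log units; within the scatter) and so stays within the scatter, which means that for this pair the methyl at this position leaves no readable mark on the number. The 2-methylphenyl and 3-methylphenyl rings also cannot be told apart, with a 1.6-fold lower number from compound 2 to compound 4 (0.21 log units; within the scatter) inside the scatter as well, whereas 2-methylphenyl in place of 6-methylpyridin-2-yl gives a 21-fold lower number from compound 1 to compound 4 (1.32 log units; beyond the scatter) and lies beyond it, so the large gap from compound 1 now holds against two differently methylated phenyl rings and not against one alone. Nothing available explains either the flat step at this position or the large gap from compound 1.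

As far as these compounds go, only methyl and hydrogen are seen at the position para to a large group, so it remains open whether a chlorine, a methoxy group, an amine, a carboxylic acid or a longer chain there would also stay within the scatter of compound 4. Also open, from the compounds shown here alone, is whether the 6-methylpyridin-2-yl gap would persist with an unsubstituted pyridin-2-yl ring compared against an unsubstituted phenyl ring.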